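From 3-hydroxypyrrolidin-1-yl to 3-carboxypyrrolidin-1-yl

This account rests on a few compounds, and the source may have more. Where it says the series, first, only, none or still open, it means among the compounds named here.

Going by the values given here, in a functional assay on MC-38 cells (Mus musculus) for antiproliferative activity, read by CCK-8 assay, with a stated time of 48 h (a higher number here means a weaker inhibitor, a lower number a stronger inhibitor), compound 2 `COc1ccc(/C=C\c2cc(OC)c(OC)c(OC)c2)cc1OCc1ccc(CN2CC[C@H](O)C2)cc1` gives 7200 nM and compound 1 `COc1ccc(/C=C\c2cc(OC)c(OC)c(OC)c2)cc1OCc1ccc(CN2CCCCC2C(=O)O)cc1` gives 5400 nM, so the only two numbers available lie within the scatter of each other. Compound 3 `COc1ccc(/C=C\c2cc(OC)c(OC)c(OC)c2)cc1OCc1ccc(CN2CC[C@@H](C(=O)O)C2)cc1` keeps the shared core of compound 2 and differs in one group: 3-carboxypyrrolidin-1-yl in place of 3-hydroxypyrrolidin-1-yl on a saturated chain carbon bound to an aromatic carbon. Here 3-carboxypyrrolidin-1-yl stands in place of 3-hydroxypyrrolidin-1-yl on a saturated chain carbon bound to an aromatic carbon. Among the compounds with values here, one measured step bears on this change: a 1.3-fold higher number from compound 1 to compound 2 (0.12 log units; within the scatter). That step exchanged 2-carboxypiperidin-1-yl for 3-hydroxypyrrolidin-1-yl at the same place and stayed within the scatter. On that single step, no change beyond the scatter is expected in this assay. The expected size is a 1.2-fold lower number from compound 2 to compound 3 (0.08 log units; within the scatter). For compound 3 the estimated value is 6000 nM, with an expected range from 2500 nM to 14000 nM.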

Compound 3, half-maximal inhibitory concentration: 6300 nM
Compound 3: middle estimate off by 1.1-fold (0.02 log units), on the low side, within the range that was stated.
By their numbers in this assay, from the lowest: compounds 1, 3 and 2 (each within the scatter of the next).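

In this assay, the exchange of the hydroxyl for the carboxyl on the pyrrolidine ring gives a 1.1-fold lower number from compound 2 to compound 3 (0.06 log units; within the scatter), and moving from 2-carboxypiperidin-1-yl to 3-carboxypyrrolidin-1-yl gives a 1.2-fold higher number from compound 1 to compound 3 (0.07 log units; within the scatter). All three groups on the saturated chain carbon bound to an aromatic carbon therefore lie within the scatter of one another, so neither the carboxylic acid in place of the hydroxyl nor the change of ring has yet separated from the scatter at this place. No data at hand bear on why these groups read alike.

As far as these compounds go, whether a simple amide, a primary amine or a longer chain carrying the carboxylic acid would move the number beyond the scatter stays open. From the compounds shown here alone, the opposite configuration of 3-carboxypyrrolidin-1-yl also stays open.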